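The source may hold more compounds than are shown below. What is called first, only, known or untested is meant among the compounds shown, and "the series" means these compounds.

Measured to date:
compound 1, `CCCCCCCCCO[C@@H]1[C@@H](N)[C@@H](O[C@H]2[C@H](O)[C@@H](O)[C@H](N)C[C@@H]2N)O[C@H](CN)[C@H]1OCCCCCCCCC` — 48.6% in a toxicity assay on the whole organism (J774 cells) for cytotoxicity, with Mus musculus as the target, read by MTT assay, with a stated time of 24 h, tested at 30 uM; a higher number here means a weaker effect of the compound at the concentration tested, a lower number a stronger effect
compound 2, `CCCCCCCCCO[C@@H]1[C@@H](N)[C@@H](OCC(O)CO)O[C@H](CN)[C@H]1OCCCCCCCCC` — 8.8%
compound 3, `CCCCCCCCCO[C@@H]1[C@@H](N)[C@@H](OC[C@@H](O)CN)O[C@H](CN)[C@H]1OCCCCCCCCC` — 7.2%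

Compound 3 gives the lowest number of the three in this assay, but its gap to compound 2 is within the scatter, so the two cannot be ordered. Only compound 1 stands apart: a number 39.8 percentage points lower from compound 1 to compound 2 (beyond the scatter) and a number 41.4 percentage points lower from compound 1 to compound 3 (beyond the scatter), both large.

Compound 4, `C=CCO[C@H]1O[C@H](CN)[C@@H](OCCCCCCCCC)[C@H](OCCCCCCCCC)[C@H]1N`, is the next member. It differs from compound 3 as follows: vinyl in place of 2-amino-1-hydroxyethyl on a saturated chain carbon bound to an oxygen on a saturated carbon. For the measured compounds named here, the only measured step at this place is a number 1.6 percentage points lower from compound 2 to compound 3 (within the scatter), a swap of one small side group for another that left the number unchanged. Going by the values given here, no measured step removes all donors and acceptors from this position and puts in a plain vinyl, so the precedent is weak. On the evidence of compound 2 and compound 3, which sit together in this assay despite differing in this side group, the expectation for compound 4 is a step of about a number 0.2 percentage points lower from compound 3 to compound 4 (within the scatter), within the scatter, and the estimated value for compound 4 is 7% (range 0% to 25%).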

Compound 4, a percentage reported as activity, at one concentration (the size of the read-out at that concentration, not a potency): 6.6%
Beside the measured number, compound 4's estimate is 0.4 percentage points above it; the range from low to high includes it.
By their numbers in this assay, from the lowest: compounds 4, 3 and 2 (each within the scatter of the next); then compound 1.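

Vinyl, counted with 0 hydrogen-bond donors and 0 hydrogen-bond acceptors, replaces side groups that carry both, and in this assay the number does not move: a number 0.6 percentage points lower from compound 3 to compound 4 (within the scatter) and a number 2.2 percentage points lower from compound 2 to compound 4 (within the scatter) together show that neither the amino nor the hydroxyl of those side groups is needed for the low number. For the compounds shown here, the one large step remains the loss of 4,6-diamino-2,3-dihydroxycyclohexyl, and a number 42 percentage points lower from compound 1 to compound 4 (beyond the scatter) shows that the short allyl group on this oxygen matches 3-amino-2-hydroxypropyl and 2,3-dihydroxypropyl in that respect. No evidence is available that explains this result.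

On these data alone, whether a plain cyclohexyl, without its amines and hydroxyls, would bring the number back up remains open. So does the effect of a carboxylic acid or a longer chain on this oxygen.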